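The source may hold more compounds than are shown below. What is called first, only, known or untested is meant among the compounds shown, and "the series" means these compounds.

Of the compounds shown here, three sharing one core have been read in a physicochemical assay for solubility, at pH 7.4; on this read-out higher numbers stand for higher solubility and lower numbers for lower solubility. Compound 1 `CCCCNc1nc(N)c2nc(O)n(Cc3ccc(OC)nc3)c2n1` gives < 1000 ug/mL, which is a limit of the assay and not a number. Compound 2 `CCCCNc1nc(N)c2[nH]c(=O)n(Cc3ccc(N(C)C)cc3)c2n1` gives 98000 ug/mL. Compound 3 `CCCCNc1nc(N)c2[nH]c(=O)n(Cc3ccc(OCCCCN(C)C)nc3)c2n1` gives 350000 ug/mL, the higher of the two actual numbers, and its gap to compound 2 lies beyond the usual scatter.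

The next compound is compound 4 `CCCCNc1nc(N)c2[nH]c(=O)n(Cc3ccc(N4CCC(N(C)C)CC4)nc3)c2n1`, not yet measured. In it, 4-(dimethylamino)piperidin-1-yl stands in place of 4-(dimethylamino)butoxy on an aromatic carbon, next to the ring nitrogen (4-(dimethylamino)piperidin-1-yl in place of 4-(dimethylamino)butoxy on an aromatic carbon). Within the data shown here, no two measured compounds differ in one place only, so no measured step can guide this change. The expectation therefore starts from compound 3 at 350000 ug/mL, and the dimethylamino end appears in both the leaving and the entering group. The expected step of a 1.2-fold lower number from compound 3 to compound 4 (0.07 log units; within the scatter) is small, with no change beyond the scatter anticipated in this assay. For compound 4 the estimated value is 300000 ug/mL, with an expected range from 90000 ug/mL to 800000 ug/mL.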

Compound 4, solubility: 71000 ug/mL
The estimate for compound 4 lay 4.2-fold (0.63 log units) above the measured number, and the stated range ends above it.
By their numbers in this assay, from the lowest: compounds 4 and 2 (each within the scatter of the next); then compound 3. At a limit, below all of these: compound 1.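

Among these compounds, the pair of compounds gives the first single-place comparison in this assay (a 4.9-fold lower number from compound 3 to compound 4 (0.69 log units; beyond the scatter)). It shows that the group on this aromatic carbon, next to the ring nitrogen, cannot be exchanged freely, even though 4-(dimethylamino)butoxy and 4-(dimethylamino)piperidin-1-yl both end in a dimethylamino group and have the same counts of hydrogen-bond donors and acceptors. Nothing measured here explains this step.

The change replaces an open chain with a six-membered non-aromatic ring and also replaces the oxygen attached to the aromatic carbon with a nitrogen, so the compounds shown do not separate these two differences. A 4-(dimethylamino)butylamino group, which keeps the chain with a nitrogen link, or a 1-methylpiperidin-4-yloxy group, which keeps a ring with an oxygen link, would bear on that question.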